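Benzyl for Cyclohexyl: an Expected Platelet Inhibition Value

The source may hold more compounds than are shown below. What is called first, only, known or untested is meant among the compounds shown, and "the series" means these compounds.

Measured compounds:
compound 1, `CCCCSc1nc(NC2CCCCC2)c2ncn([C@@H]3O[C@H](CO)[C@@H](O)[C@H]3O)c2n1`, 83000 nM
compound 2, `CCSc1nc(NC2CCCCC2)c2ncn([C@@H]3O[C@H](CO)[C@@H](O)[C@H]3O)c2n1`, 104000 nM
compound 3, `COc1ccc(CNc2nc(SC)nc3c2ncn3[C@@H]2O[C@H](CO)[C@@H](O)[C@H]2O)cc1`, "not determined" (no result reported)

In a functional assay on a cell-free system (Platelet, plasma, Homo sapiens) for inhibition, with stated times of 1 min and 3 min (a lower number here means a stronger inhibitor, a higher number a weaker inhibitor), compound 1 gives 83000 nM and compound 2 gives 104000 nM. Compound 2 therefore stands highest of the two numbers available, but its nearest neighbour is compound 1, and the step of a 1.3-fold higher number from compound 1 to compound 2 (0.10 log units; within the scatter) lies within the scatter, so the two cannot be ordered. That single measured step concerns hydrogen in place of ethyl on a saturated chain carbon, two bonds along the chain from a sulfur, and leaves the nitrogen substituent untouched.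

Compound 4, `CCSc1nc(NCc2ccccc2)c2ncn([C@@H]3O[C@H](CO)[C@@H](O)[C@H]3O)c2n1`, has not yet been measured. It differs from compound 2 by benzyl in place of cyclohexyl on a nitrogen on an aromatic ring. Within the data shown here, no measured step touches that position: compound 3 carries a related benzyl-type group together with a different sulfur chain, but in this assay compound 3 shows "not determined" (no result reported), so nothing in the data speaks to the size or direction of this change. Among the measured compounds shown here, with no step bearing on it, the expectation for compound 4 is no movement beyond the scatter, a 1.0-fold lower number from compound 2 to compound 4 (0.02 log units; within the scatter), with a wide margin on either side. The estimated value for compound 4 in this assay is 100000 nM, in the range 30000 nM to 300000 nM.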

Compound 4, half-maximal inhibitory concentration: 176000 nM
Beside the measured number, compound 4's estimate is 1.8-fold (0.25 log units) below it; low and high end bracket the measured number.
By their numbers in this assay, from the lowest: compounds 1, 2 and 4 (each within the scatter of the next, the first and the last beyond it).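

In this assay, the exchange of cyclohexyl for benzyl on a nitrogen on an aromatic ring now has a reading of its own: a 1.7-fold higher number from compound 2 to compound 4 (0.23 log units; within the scatter). Among these compounds, the earlier compounds varied only the chain on the sulfur, so this is the first view of the nitrogen substituent, and it shows that replacing the non-aromatic ring with the aromatic ring of benzyl, which brings one more carbon, does not move the number beyond the scatter, leaving compound 2 and compound 4 without an order. No independent measurement accompanies these numbers to explain them.

The compounds shown leave open whether a quite different substituent on this nitrogen, such as a phenethyl group, a simple amine-bearing chain or a carboxylic acid, would move the number beyond the scatter, since cyclohexyl and benzyl are the only two groups here with readable values. They also leave open whether benzyl would behave the same way with a butyl chain on the sulfur, as that chain appears here only together with cyclohexyl.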